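The source may report more compounds than this note shows. Statements on the series, on what has been measured and on what is new or still open speak of the compounds shown alone.

In a functional assay on NCI-H460 cells (Homo sapiens) for inhibition, read by MTT assay, with a stated time of 72 h (on this read-out lower numbers stand for stronger inhibition and higher numbers for weaker inhibition), compound 2 `COc1ccc(-n2nc(C(=O)Nc3ccc(Oc4ccnc5cc(OCCCN6CCCCC6)c(OC)cc45)c(F)c3)c(C)cc2=O)cc1` gives 3730 nM, the highest of the two numbers shown. Going by the values given here, compound 1 `COc1cc2c(Oc3ccc(NC(=O)c4nn(-c5ccccc5)c(=O)cc4C)cc3F)ccnc2cc1OCCCN1CCCCC1` gives 280 nM in this assay, and the single measured step, a 13-fold higher number from compound 1 to compound 2 (1.12 log units; beyond the scatter), is large. Compound 3 `COc1cc2c(Oc3ccc(NC(=O)c4nn(-c5ccc(Cl)cc5)c(=O)cc4C)cc3F)ccnc2cc1OCCCN1CCCCC1` differs from compound 2 by chloro in place of methoxy on an aromatic carbon. Among the compounds with values here, no measured step introduces chloro; only the loss of the methoxy has a precedent, in reverse, in that large step. A move back toward a lower number is therefore expected, its size uncertain. Compound 3 is estimated at 700 nM, with a range from 200 nM to 2500 nM, meaning an expected step of a 5.3-fold lower number from compound 2 to compound 3 (0.73 log units; beyond the scatter).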

Compound 3, half-maximal inhibitory concentration: 460 nM
Beside the measured number, compound 3's estimate is 1.5-fold (0.18 log units) above it; the range from low to high includes it.
By their numbers in this assay, from the lowest: compounds 1 and 3 (each within the scatter of the next); then compound 2.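

In this assay, chloro at the position para to a large group gives an 8.1-fold lower number from compound 2 to compound 3 (0.91 log units; beyond the scatter), so the high number of compound 2 does not extend to every replacement of hydrogen here. Chloro in place of hydrogen gives a 1.6-fold higher number from compound 1 to compound 3 (0.22 log units; within the scatter), which lies within the scatter, whereas methoxy at the same position gives a 13-fold higher number from compound 1 to compound 2 (1.12 log units; beyond the scatter). Nothing measured here explains why the two groups differ. The compounds shown leave open how an amine, a hydroxyl group or a longer ether chain would read at this position.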